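Chloro-to-hydrogen swap on chromone thioethers: cytotoxicity notes

A few compounds are considered here, and "the series" means these few. Any claim that something is new, unique, unknown or untested is made for them only; others in the source may bear on it.

The series is built on a chromone bearing a thiomethyl-linked heteroaryl group. Compound 1 `O=c1cc(CSc2nc3ccccc3s2)oc2ccccc12` and compound 2 `O=c1cc(CSc2nc3ccccc3s2)oc2ccc(Cl)cc12` share one core; compound 3 `Cc1cc(C)n2nc(SCc3cc(=O)c4cc(Cl)ccc4o3)nc2n1` and compound 4 `Cc1cc(C)n2nc(SCc3cc(=O)c4ccccc4o3)nc2n1` share another. The difference between the two cores is not broken down here.

All activity so far comes from a functional assay on LM7 cells (Homo sapiens) for cytotoxicity, read by MTT assay, with a stated time of 72 h; on this read-out higher numbers stand for weaker inhibition and lower numbers for stronger inhibition. In this assay compound 1 gives > 25000 nM, which is a limit of the assay and not a number. Compound 2 gives > 25000 nM, again a limit. Compound 3 gives > 25000 nM, likewise a limit.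

Among the measured compounds shown here, the one step that can be drawn is a step that the two limits leave unreadable from compound 2 to compound 1, the change being (hydrogen in place of chloro on an aromatic carbon). Both ends of that step sit at the limit of > 25000 nM in this assay, at which 3 of the 3 values shown sit, so no direction or size can be read from it.

Compound 4 carries the same change relative to compound 3, namely (hydrogen in place of chloro on an aromatic carbon); the place described for both swaps is the same word for word, so this is the same change, not merely the same kind. For the measured compounds named here, since compound 3 itself sits at the limit, and the only measured example of this change, from compound 2 to compound 1, left both ends at the limit, the step from compound 3 to compound 4 is expected to be a step that the limit leaves unreadable from compound 3 to compound 4. Compound 4 is therefore estimated at 30000 nM in this assay, with a range from 12000 nM to 100000 nM, and most likely reported only as a limit.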

Compound 4, half-maximal inhibitory concentration: > 25000 nM
Compound 4: only a limit was reported; the forecaster's own chance of this, stated with the estimate: 85%; the middle value lies beyond the limit too.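

In this assay compound 4 gives > 25000 nM, a limit of the assay and not a number. No new step can be read, as the change from compound 3 to compound 4 leaves both ends at the limit: the limit of > 25000 nM in this assay, at which 4 of the 4 values shown sit.

The compounds shown leave open whether hydrogen in place of chloro changes cytotoxicity on either core, and whether the two cores differ at all in this assay.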